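The source may hold more compounds than are shown below. What is called first, only, known or untested is meant among the compounds shown, and "the series" means these compounds.

In a physicochemical assay for solubility, read by HPLC, in phosphate buffer, with a stated time of 16 h, at pH 6.8 (on this read-out lower numbers stand for lower solubility and higher numbers for higher solubility), compound 1 `Cc1ccc([C@H](C)NC(=O)Cn2nnc3ccccc3c2=O)cc1` gives 12000 nM, compound 2 `COc1cccc2nnn(CC(=O)N[C@@H](C)c3ccc(C)cc3)c(=O)c12` gives 9300 nM and compound 3 `C[C@H](NC(=O)Cn1nnc2ccccc2c1=O)c1ccc(OC(F)F)cc1` gives 2400 nM, the lowest of the three numbers. Compound 4 `COc1cccc2nnn(CC(=O)N[C@@H](C)c3ccc(OC(F)F)cc3)c(=O)c12` has not been measured yet. It differs from compound 3 by methoxy in place of hydrogen on an aromatic carbon, with methoxy in place of hydrogen on an aromatic carbon. The same replacement has been measured once, and there it gave a 1.3-fold lower number from compound 1 to compound 2 (0.11 log units; within the scatter). Going by the values given here, the only other measured step, a 5.0-fold lower number from compound 1 to compound 3 (0.70 log units; beyond the scatter), puts difluoromethoxy in place of methyl, a different change, so it offers little guidance here. With one small precedent, no change beyond the scatter is expected in this assay, and the expected step is a 1.3-fold lower number from compound 3 to compound 4 (0.10 log units; within the scatter). For compound 4 the estimated value is 1900 nM, with an expected range from 900 nM to 4000 nM.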

Compound 4, solubility: 9600 nM
Beside the measured number, compound 4's estimate is 5.1-fold (0.70 log units) below it; measured number outside the range, above it.
By their numbers in this assay, from the lowest: compound 3; then compounds 2, 4 and 1 (each within the scatter of the next).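

In this assay methoxy on this aromatic carbon does not give one fixed step: with difluoromethoxy in the molecule the result is a 4.0-fold higher number from compound 3 to compound 4 (0.60 log units; beyond the scatter), while with methyl in its place it was a 1.3-fold lower number from compound 1 to compound 2 (0.11 log units; within the scatter) and stayed within the scatter. The difluoromethoxy change also reads differently with methoxy present, giving a 1.0-fold higher number from compound 2 to compound 4 (0.01 log units; within the scatter) rather than a 5.0-fold lower number from compound 1 to compound 3 (0.70 log units; beyond the scatter), so the two replacements do not simply add up. Nothing shown here explains this difference. Going by these compounds, whether an ethoxy group or an amine on the same carbon would depend on its partner group in the same way stays open.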